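Chloro in Place of Hydrogen on the Ethenyl Phenyl

A few compounds are considered here, and "the series" means these few. Any claim that something is new, unique, unknown or untested is made for them only; others in the source may bear on it.

The study compares four compounds built on a common sulfonamide-bearing core. Compound 1 `NS(=O)(=O)c1cc(-c2nnc(CN3CCN(c4ccccc4)CC3)o2)c(Cl)cc1SCc1ccccc1` and compound 2 `NS(=O)(=O)c1cc(-c2nnc(CN3CCN(c4ccc(Cl)cc4)CC3)o2)c(Cl)cc1SCc1ccccc1` carry a piperazine-linked phenyl at the end of the chain, while compound 3 `NS(=O)(=O)c1cc(-c2nnc(/C=C/c3ccccc3)o2)c(Cl)cc1SCc1ccccc1` and compound 4 `NS(=O)(=O)c1cc(-c2nnc(/C=C/c3cccc(Cl)c3)o2)c(Cl)cc1SCc1ccccc1` carry a 2-phenylethenyl group there. In a functional assay on MCF7 cells (Homo sapiens) for cytotoxicity, read by MTT assay, with a stated time of 72 h (on this read-out higher numbers stand for weaker inhibition and lower numbers for stronger inhibition), compound 1 gives 295000 nM, compound 2 gives 280000 nM, and compound 3 gives 16000 nM. The change from compound 1 to compound 2 is chloro in place of hydrogen on an aromatic carbon, and it made a 1.1-fold lower number from compound 1 to compound 2 (0.02 log units; within the scatter). How the core of compound 3 differs from the core of compound 1 is not broken down here; the two values simply show that compound 3 has the lowest of the three numbers in this assay, with both compound 1 and compound 2 lying well above it.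

Compound 4 has not yet been measured. It differs from compound 3 by chloro in place of hydrogen on an aromatic carbon. For the measured compounds named here, this is the same kind of change as the one from compound 1 to compound 2, but not the same: in the earlier pair the chlorine enters para to a large group, here it enters meta to a large group. Because a 1.1-fold lower number from compound 1 to compound 2 (0.02 log units; within the scatter) stayed within the scatter, the author expects a similarly small step, namely no change at the digits printed from compound 3 to compound 4 (within the scatter). Compound 4 is therefore estimated at 16000 nM in this assay, with a range from 7000 nM to 36000 nM.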

Compound 4, half-maximal inhibitory concentration: 11000 nM
Estimate against measurement, compound 4: 1.5-fold (0.16 log units) above, and the stated range covers the measured number.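

In this assay, for the compounds shown here, chloro in place of hydrogen on the phenyl of the 2-phenylethenyl group gave a 1.5-fold lower number from compound 3 to compound 4 (0.16 log units; within the scatter), so this step, like the one on the piperazine-linked pair, stays within the scatter. Set side by side, the two steps do not differ, and within this small set the change carries from one core to the other without a difference that can be read: the same change on two cores in this assay, a 1.1-fold lower number (0.02 log units; within the scatter) from compound 1 to compound 2 and a 1.5-fold lower number (0.16 log units; within the scatter) from compound 3 to compound 4, 1.4-fold (0.14 log units) apart, within the scatter of two such steps. Going by these compounds alone, this does not show that the change would leave the number in place on every core, for it rests on only two pairs in one assay, and the chlorine does not occupy the same position in the two pairs, so the effect of the core cannot be separated from that of the position.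

The compounds shown leave open whether another group on the same phenyl, such as a fluoro, a methoxy, an amine or a carboxylic acid, would give a step beyond the scatter. They also leave open whether chloro at other positions on the phenyl of the 2-phenylethenyl group would behave as it does in compound 4, and whether a saturated two-carbon chain in place of the ethenyl link would keep the number near that of compound 3.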